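This account rests on a few compounds, and the source may have more. Where it says the series, first, only, none or still open, it means among the compounds named here.

Working notes on the series. Compound 1 `Cc1cc(-c2sc(Cc3cccc(C(F)(F)F)c3)nc2C)ccc1C(N)=O` is the reference point; in a functional assay on cells for agonist activity at G-protein coupled receptor 52 (Homo sapiens), read by AlphaScreen and cAMP accumulation, with a stated time of 30 min (a higher number here means that more compound is needed for the effect, a lower number that less compound is needed), compound 1 gives 73 nM. Compound 2 `Cc1nc(Cc2cccc(C(F)(F)F)c2)sc1-c1ccc(C(N)=O)c(F)c1` carries fluoro where compound 1 carries methyl, and in this assay compound 2 gives 380 nM. Within the data shown here, the single measured step, a 5.2-fold higher number from compound 1 to compound 2 (0.72 log units; beyond the scatter), is the only step so far. On the two numbers available, compound 2 stands at the higher one, with compound 1 the nearer and only neighbour.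

Compound 3 `COc1cc(-c2sc(Cc3cccc(C(F)(F)F)c3)nc2C)ccc1C(N)=O` is not yet measured. It differs from compound 2 by methoxy in place of fluoro on an aromatic carbon, on an aromatic carbon of a six-membered aromatic ring of carbon only, ortho to a carbamoyl group and meta to a large group. Among the measured compounds shown here, the one step that bears on this position is a 5.2-fold higher number from compound 1 to compound 2 (0.72 log units; beyond the scatter), which shows that fluoro here gave a clearly higher number than methyl. Methoxy is a third group at the same place, so a step back toward the number of compound 1 is expected, though no measured pair shows methoxy directly. The step from compound 2 to compound 3 is therefore expected to be a 2.9-fold lower number from compound 2 to compound 3 (0.47 log units; beyond the scatter), and for compound 3 the expected value in this assay is 130 nM, within 40 nM to 400 nM.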

Compound 3, half-maximal effective concentration: 170 nM
Beside the measured number, compound 3's estimate is 1.3-fold (0.12 log units) below it; the measured number falls inside the stated range.
By their numbers in this assay, from the lowest: compound 1; then compound 3; then compound 2.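

Three groups can now be compared at this one place, on the aromatic carbon ortho to a carbamoyl group, and in this assay their order from the lowest number is methyl, methoxy, fluoro. Methoxy recovers only part of what fluoro lost, with a 2.2-fold lower number from compound 2 to compound 3 (0.35 log units; beyond the scatter), while methyl remains ahead of methoxy, with a 2.3-fold higher number from compound 1 to compound 3 (0.37 log units; beyond the scatter), so both steps show that this place still separates the groups beyond the scatter when the change is methoxy. No supporting measurement on these compounds accounts for this order.

What the compounds leave open is whether any other group at this place, such as ethyl, chloro, hydroxyl or a nitrile, or plain hydrogen, would give a number lower than that of compound 1 or would fall within the range of the three groups so far. Also open, going by these compounds, is whether the order methyl, methoxy, fluoro would hold if the carbamoyl group or the trifluoromethyl group of the shared core were replaced, for instance by a carboxylic acid or a chloro group.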